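Trimethoxyphenyl Replaces Cyanophenyl on a Shared Urea Core

The source may hold more compounds than are shown below. What is called first, only, known or untested is meant among the compounds shown, and "the series" means these compounds.

Measured so far:
compound 1 `Cc1ccsc1CN(C(=O)Nc1ccc(Cl)c(C(F)(F)F)c1)n1cnnc1` 22100 nM
compound 2 `N#Cc1ccc(CN(C(=O)Nc2cc(C(F)(F)F)cc(C(F)(F)F)c2)n2cnnc2)cc1` 4510 nM

Of the compounds shown here, two have been measured in a functional assay on B16-F10 cells (Mus musculus) for cytotoxicity, read by MTT assay, with a stated time of 48 h; on this read-out lower numbers stand for stronger inhibition and higher numbers for weaker inhibition. Compound 1 gives 22100 nM, and compound 2 gives 4510 nM, the lower of the two numbers; the gap between them lies beyond the usual scatter. The two differ in more than one place, so nothing is known about what any single change contributes.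

Compound 3 `COc1cc(CN(C(=O)Nc2cc(C(F)(F)F)cc(C(F)(F)F)c2)n2cnnc2)cc(OC)c1OC` is not yet measured. It differs from compound 2 in one place: 3,4,5-trimethoxyphenyl in place of 4-cyanophenyl on a saturated chain carbon bound to an amide-type nitrogen. Compound 3 keeps the rest of compound 2 unchanged.

Going by the values given here, no measured pair shows the effect of a change at this position, so the direction of the step is uncertain. With that in mind, compound 3 is expected to give roughly 5000 nM in this assay, somewhere in the range 1200 nM to 20000 nM. The step this estimate implies is expected to be a 1.1-fold higher number from compound 2 to compound 3 (0.04 log units; within the scatter), which may well stay within the scatter.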

Compound 3, half-maximal inhibitory concentration: 5620 nM
For compound 3 the middle estimate is 1.1-fold (0.05 log units) below the measured one; the range from low to high includes it.
By their numbers in this assay, from the lowest: compounds 2 and 3 (each within the scatter of the next); then compound 1.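

In this assay the exchange of 4-cyanophenyl for 3,4,5-trimethoxyphenyl on a saturated chain carbon bound to an amide-type nitrogen gives a 1.2-fold higher number from compound 2 to compound 3 (0.10 log units; within the scatter) and so leaves the two compounds indistinguishable. Going by these compounds alone, this is the first reading of a single change at this position, and it shows that, with the rest of compound 2 kept, a nitrile-bearing phenyl and a phenyl with three methoxy groups give values that cannot be told apart. Nothing available bears on why these two groups read alike.

From the compounds shown here alone, it remains open whether a phenyl carrying an amine or a carboxylic acid, or a plain longer chain in place of the ring, would move the number beyond the scatter. Compound 1 differs from the other two in more than one place, so its steps to them cannot be read.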